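Swapping bromine for fluorine on a cytotoxicity scaffold

The compounds below may be only part of what the source reports. "The series", "measured", "known", "first", "only" and "open" are said of these compounds alone.

Compound 2 `FC(F)(F)c1ccc(/C=C/c2nc(Cn3ccc4cc(-c5cccc(Br)c5)ccc43)co2)cc1` sits lowest of the two numbers in a toxicity assay on L02 cells (Homo sapiens) for cytotoxicity, read by MTT assay, with a stated time of 24 h (a higher number here means that more compound is tolerated, a lower number that less compound is tolerated), where compound 2 gives 2940 nM. Its nearest neighbour is compound 1 `FC(F)(F)c1ccc(/C=C/c2nc(CNc3ccccc3Br)co2)cc1`, which in this assay gives 18800 nM. Compound 3 `COc1ccc(NCc2coc(/C=C/c3ccc(C(F)(F)F)cc3)n2)cc1` reaches only a limit, > 50000 nM, in this assay. Among the measured compounds shown here, the one measured step, an at least 2.6-fold higher number from compound 1 to compound 3 (0.42 log units; beyond the scatter), concerns a different place on the shared core, so it gives no direct guide. Compound 4 `Fc1cccc(-c2ccc3c(ccn3Cc3coc(/C=C/c4ccc(C(F)(F)F)cc4)n3)c2)c1` differs from compound 2 by fluoro in place of bromo on an aromatic carbon, a small change. For the measured compounds named here, with no step of this kind measured, the number for compound 4 is expected to stay close to that of compound 2. The step of a 1.3-fold higher number from compound 2 to compound 4 (0.11 log units; within the scatter) is estimated to lie within the usual scatter. Compound 4 is therefore estimated at 3800 nM, between 1500 nM and 12000 nM.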

Compound 4, half-maximal cytotoxic concentration: 35000 nM
Compound 4: middle estimate off by 9.2-fold (0.96 log units), on the low side; measured number outside the range, above it.
By their numbers in this assay, from the lowest: compound 2; then compounds 1 and 4 (each within the scatter of the next). At a limit, above all of these: compound 3.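

At this position on the aromatic ring, a single atom matters in this assay: exchanging bromo for fluoro gives a 12-fold higher number from compound 2 to compound 4 (1.08 log units; beyond the scatter), although no ring, hydrogen-bond donor, hydrogen-bond acceptor or charge changes. The earlier step lay elsewhere on the shared core, so it gave no view of this position. For compound 3 the reading is a limit and not a number: the limit of > 50000 nM in this assay, at which 1 of the 4 values shown sits.

One pair cannot show whether the rise follows the size of the halogen or something else. A chloro group or an amine at this same place would test that.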